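Swapping a Chain for an Acyl Group on a Cytotoxicity Core

This account rests on a few compounds, and the source may have more. Where it says the series, first, only, none or still open, it means among the compounds named here.

Three compounds have so far been examined in an ADME assay on HepG2 2.2.15 cells (Homo sapiens) for cytotoxicity; a higher number here means that more compound is tolerated, a lower number that less compound is tolerated. Compound 1 `Cc1cc(C(C)C)ccc1OC(c1ccc(Cl)cc1)c1cnc(NC(=O)OC(C)(C)C)s1` gives a value that is a limit of the assay rather than a number, namely > 50000 nM. Compound 2 `Cc1ccc(COC(c2ccccc2)c2cnc(NC(=O)c3cccs3)s2)cc1` is recorded in this assay only as "not toxic" (no number reported), with no number attached. Compound 3 `COCCNc1ncc(C(Oc2ccc3cc(Br)ccc3c2)c2ccc(Cl)cc2)s1` is likewise recorded in this assay as "not toxic" (no number reported), again without a number.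

Where compound 3 stands can be said only loosely: no single number exists for it, one of the three values shown is a limit, and the remaining entry also carries no number. The one firm point is the limit of > 50000 nM in this assay, at which 1 of the 3 values shown sits.

Compound 4 `O=C(Nc1ncc(C(Oc2ccc3cc(Br)ccc3c2)c2ccc(Cl)cc2)s1)c1ccc(Cl)nc1` is the next compound to be measured in this assay. It differs from compound 3 in one place: (6-chloropyridin-3-yl)carbonyl in place of 2-methoxyethyl on a nitrogen on an aromatic ring. For the measured compounds named here, no step between two measured compounds is available to show what such a change does to cytotoxicity. All three measured compounds were tolerated to the limit or reported as not toxic, so the expected step in this assay is none beyond the scatter, with the outcome again likely to be a limit. Compound 4 is expected to give an estimated 50000 nM in this assay, within a range from 20000 nM to 100000 nM.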

Compound 4, half-maximal cytotoxic concentration: "not toxic" (no number reported)
The entry for compound 4 holds no number, and the estimate cannot be compared.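

Compound 3 and compound 4 are both recorded in this assay only as not toxic, with no number, so no step can be read between them. The only firm point remains a limit: the limit of > 50000 nM in this assay, at which 1 of the 4 values shown sits. The compounds shown leave open whether replacing 2-methoxyethyl with (6-chloropyridin-3-yl)carbonyl changes the concentration tolerated, and by how much.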